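This account rests on a few compounds, and the source may have more. Where it says the series, first, only, none or still open, it means among the compounds named here.

Measured compounds:
compound 1 `CC(C)(C)OC(=O)N1CCc2c(sc(NC(=O)c3ccc(Oc4ccccc4)cc3)c2C(N)=O)C1` gives 26.9%
compound 2 `NC(=O)c1c(NC(=O)c2ccc(Oc3ccccc3)cc2)sc2c1CCN(Cc1ccccc1)C2` gives 23.6%
compound 3 `CC(C)(C)OC(=O)N1CCc2c(sc(NC(=O)c3ccc(OCc4ccccc4)cc3)c2C(N)=O)C1` gives 52.1%

These three compounds were tested in an ADME assay on RAW264.7 cells (Mus musculus) for cytotoxicity, read by MTT assay, with a stated time of 48 h, tested at 50 uM; on this read-out lower numbers stand for less inhibition and higher numbers for more inhibition at the one concentration tested (going by the name of the read-out). In this assay compound 1 gives 26.9% and compound 2 gives 23.6%. The two differ in one place, (benzyl in place of tert-butoxycarbonyl on an amine nitrogen in a ring), and the step is a number 3.3 percentage points lower from compound 1 to compound 2 (within the scatter). Compound 3 gives 52.1%, and it differs from compound 1 by benzyl in place of phenyl on an oxygen on an aromatic ring, a step of a number 25.2 percentage points higher from compound 1 to compound 3 (beyond the scatter). Compound 3 thus stands apart from both of the other two.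

Compound 4 `NC(=O)c1c(NC(=O)c2ccc(OCc3ccccc3)cc2)sc2c1CCN(Cc1ccccc1)C2` has not yet been measured. It differs from compound 3 by benzyl in place of tert-butoxycarbonyl on an amine nitrogen in a ring. This is the same change that turns compound 1 into compound 2, made on a core that differs from the core of compound 1 by benzyl in place of phenyl on an oxygen on an aromatic ring. When this change was made from compound 1 to compound 2, the result was a number 3.3 percentage points lower from compound 1 to compound 2 (within the scatter), a shift that lies within the usual scatter. If the change behaves the same way on the core of compound 3, compound 4 is expected to stay near compound 3, with an estimated step of a number 3.1 percentage points lower from compound 3 to compound 4 (within the scatter). The only reason to widen the range is that one earlier example cannot show whether the change acts alike on both cores.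

Compound 4 is expected to give about 49% in this assay, with an estimated range from 34% to 64%.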

Compound 4, a percentage reported as inhibition, at one concentration (the size of the read-out at that concentration, not a potency): 24%
Compound 4: the middle estimate sits 25 percentage points above what was measured, and the stated range ends above it.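

In this assay, the step from tert-butoxycarbonyl to benzyl on the amine nitrogen in a ring does not carry over from the core of compound 1 to the core of compound 3, for on the latter core it is a number 28.1 percentage points lower from compound 3 to compound 4 (beyond the scatter), and the two results disagree: the same change on two cores in this assay, a number 3.3 percentage points lower (within the scatter) from compound 1 to compound 2 and a number 28.1 percentage points lower (beyond the scatter) from compound 3 to compound 4, 24.8 percentage points apart, beyond the scatter of two such steps

The other change, benzyl in place of phenyl on an oxygen on an aromatic ring, also fails to carry over, giving a number 0.4 percentage points higher from compound 2 to compound 4 (within the scatter) on the cores that bear benzyl on the ring nitrogen, which sets it apart from its earlier result: the same change on two cores in this assay, a number 25.2 percentage points higher (beyond the scatter) from compound 1 to compound 3 and a number 0.4 percentage points higher (within the scatter) from compound 2 to compound 4, 24.8 percentage points apart, beyond the scatter of two such steps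

So the two changes do not simply add up in these four compounds, and the effect of each depends on the group held at the other place, but this single set of four does not show why this happens or how either change would behave on any further core.

As far as these compounds go, it remains open whether the raised number of compound 3 needs tert-butoxycarbonyl specifically, or would also appear with another group on the ring nitrogen, such as acetyl or methyl. From the compounds shown here alone, it is equally open how a longer chain or a simple methyl on the oxygen would behave on either core.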